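Hydroxymethyl for chloro on the benzyl group

The compounds below may be only part of what the source reports. "The series", "measured", "known", "first", "only" and "open" are said of these compounds alone.

The series shares one core, seen in compound 1 `CCOC(=O)c1nc(C)c2c(c1N)C(=O)N(Cc1ccccc1)C2=O` and compound 2 `Cc1nc(C(=O)NC#N)c(N)c2c1C(=O)N(Cc1ccccc1)C2=O`. In a physicochemical assay for solubility, using the shake flask method, in simulated intestinal fluid, measured as kinetic solubility, with a stated time of 2 h, at 25 degrees C, at pH 6.5 (a higher number here means a more soluble compound, a lower number a less soluble compound), compound 1 gives only a limit, < 5000 nM. In this assay compound 2 gives 185000 nM. Going by the values given here, the single measured step, an at least 37-fold higher number from compound 1 to compound 2 (1.56 log units; beyond the scatter), concerns a group on a carbonyl carbon and not the benzyl ring. Compound 3 `Cc1noc(-c2nc(C)c3c(c2N)C(=O)N(Cc2ccc(Cl)cc2)C3=O)n1` carries a 4-chlorobenzyl group. In this assay compound 3 gives only a limit, < 5000 nM. Two of the three measurements sit at that limit, as noted in the limit of < 5000 nM in this assay, at which 2 of the 3 values shown sit. Compound 4 `Cc1noc(-c2nc(C)c3c(c2N)C(=O)N(Cc2ccc(CO)cc2)C3=O)n1` differs from compound 3 in one place: hydroxymethyl in place of chloro on an aromatic carbon. Among the compounds with values here, no measured step matches this change, so the step from compound 1 to compound 2 bears on it only loosely, and with compound 3 at a limit the starting point itself is not a number. Compound 4 is expected to give a higher number than compound 3, estimated as 15000 nM, within 3000 nM to 80000 nM. The step of an at least 3.0-fold higher number from compound 3 to compound 4 (0.47 log units; beyond the scatter) is thus expected to be modest and uncertain.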

Compound 4, solubility: < 5000 nM
Compound 4: no number, only a limit; the forecaster's own chance of this, stated with the estimate: 30%; at least 3.0-fold (0.47 log units) between middle value and limit.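

In this assay, going by these compounds alone, compound 3 and compound 4 both give only a limit, so no step between them can be read: the limit of < 5000 nM in this assay, at which 3 of the 4 values shown sit. The compounds shown leave open how far each lies from that limit, and whether hydroxymethyl in place of chloro changes the read-out at all.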